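The compounds below may be only part of what the source reports. "The series", "measured", "known", "first", "only" and "open" are said of these compounds alone.

All four compounds share one core and are judged in a functional assay on U-87MG ATCC cells for antiproliferative activity against U-87 MG (Homo sapiens), read by MTT assay, with a stated time of 72 h; on this read-out lower numbers stand for stronger inhibition and higher numbers for weaker inhibition. The three measured so far:

Compound 1 `Cc1nn(C)c(Oc2ccc(Br)cc2)c1/C=N\CCCCCOc1cc2oc(=O)cc(C)c2cc1Cl` gives 15300 nM.
Compound 2 `Cc1nn(C)c(Oc2ccc(I)cc2)c1/C=N\CCCCCOc1cc2oc(=O)cc(C)c2cc1Cl` gives > 25000 nM, which is a limit of the assay and not a number.
Compound 3 `Cc1nn(C)c(Oc2ccc(Br)cc2)c1/C=N\CCCCCCOc1cc2oc(=O)cc(C)c2cc1Cl` gives 5420 nM.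

Between compound 1 and compound 2 the only change is iodo in place of bromo on an aromatic carbon, and this gave an at least 1.6-fold higher number from compound 1 to compound 2 (0.21 log units; that floor lies within the scatter). The step cannot be sized more closely, since compound 2 sits at the limit of > 25000 nM in this assay, at which 1 of the 3 values shown sits. Compound 3 differs from compound 1 in more than one place; the difference between the two cores is not broken down here. Its number stands lowest of the two numbers shown.

Compound 4 `Cc1nn(C)c(Oc2ccc(I)cc2)c1/C=N\CCCCCCOc1cc2oc(=O)cc(C)c2cc1Cl` is not yet measured. It differs from compound 3 by iodo in place of bromo on an aromatic carbon, the same change that turned compound 1 into compound 2, at the same place. Compound 4 is therefore expected to lie weaker than compound 3 by about a 1.8-fold higher number from compound 3 to compound 4 (0.24 log units; within the scatter), resting on the earlier step of an at least 1.6-fold higher number from compound 1 to compound 2 (0.21 log units; that floor lies within the scatter) from compound 1. The estimate for compound 4 is 9500 nM, likely between 4500 nM and 22000 nM.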

Compound 4, half-maximal inhibitory concentration: 16800 nM
For compound 4 the middle estimate is 1.8-fold (0.25 log units) below the measured one, within the range that was stated.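

In this assay, iodo in place of bromo gives a 3.1-fold higher number from compound 3 to compound 4 (0.49 log units; beyond the scatter), a step large enough to stand out from ordinary repeat variation, and the same swap on the core of compound 1 points the same way, though less firmly. Side by side, the two results suggest that the direction of this change can carry from one core to the other in this small set, but they do not show that its size carries over as well: the same change on two cores in this assay, an at least 1.6-fold higher number (0.21 log units; that floor lies within the scatter) from compound 1 to compound 2 and a 3.1-fold higher number (0.49 log units; beyond the scatter) from compound 3 to compound 4; the limit leaves it open whether they differ

The first step can only be given as a minimum, since compound 2 gives a limit of the assay and not a true number: the limit of > 25000 nM in this assay, at which 1 of the 4 values shown sits.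

On these data alone, with only bromo and iodo compared on two cores, it remains open whether chloro, fluoro or a methoxy group at the same place on the phenoxy ring would continue this trend. As far as these compounds go, it also remains open whether the swap would behave the same way on a core with a longer chain than that of compound 3.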